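The source may hold more compounds than are shown below. What is called first, only, known or untested is meant among the compounds shown, and "the series" means these compounds.

Of the compounds shown here, two carrying the same core have been measured. Compound 1 `CCOc1c(-c2occ(C)c2C(=O)OC)ccc2c(CC)cccc12` bears a methoxycarbonyl group on the furan-type ring, and in a functional assay on KB cells (Homo sapiens) for cytotoxicity, read by MTT assay, with a stated time of 72 h (on this read-out lower numbers stand for an effect already at smaller amounts and higher numbers for an effect only at larger amounts of compound), compound 1 gives 1.8 ug/mL. Compound 2 `CCOc1c(-c2occ(C)c2CO)ccc2c(CC)cccc12` carries a hydroxymethyl group in that position instead. In this assay compound 2 gives > 10 ug/mL, which is a limit of the assay rather than a number. The change between them is an at least 5.5-fold higher number from compound 1 to compound 2 (0.74 log units; beyond the scatter), and this rests on (the limit of > 10 ug/mL in this assay, at which 1 of the 2 values shown sits).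

Compound 3 `CCOc1c(-c2occ(C)c2COC)ccc2c(CC)cccc12` differs from compound 2 by methyl in place of hydrogen on an oxygen on a saturated carbon. Within the data shown here, no measured step covers this kind of change; the only step known concerns a different group, so it gives little guidance. Compound 3 is therefore expected to sit near its neighbour, at about 8 ug/mL, with a likely range from 3 ug/mL to 20 ug/mL. That estimate corresponds to an at least 1.2-fold lower number from compound 2 to compound 3 (0.09 log units; that floor lies within the scatter), an expected change within the usual scatter.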

Compound 3, concentration for half-maximal effect: > 10 ug/mL
Compound 3 ended at the assay's limit; the forecaster's own chance of this, stated with the estimate: 50%; at least 1.2-fold (0.09 log units) between middle value and limit.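

In this assay compound 3 gives > 10 ug/mL, which is a limit of the assay and not a number. Methoxymethyl in place of methoxycarbonyl on this aromatic carbon gives an at least 5.5-fold higher number from compound 1 to compound 3 (0.74 log units; beyond the scatter), so putting methyl in place of the hydrogen on the oxygen of hydroxymethyl does not bring back a readable number. The step from compound 2 to compound 3 cannot be read, because the values of both compounds stop at the same limit: the limit of > 10 ug/mL in this assay, at which 2 of the 3 values shown sit.

Among the compounds shown, only compound 1, with its methoxycarbonyl group, gives a readable number, so it stays open whether the carbonyl alone or the whole ester matters. A carboxylic acid or a primary amide on this aromatic carbon would keep the carbonyl without the methoxy part and could help to separate the two.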